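This account rests on a few compounds, and the source may have more. Where it says the series, first, only, none or still open, it means among the compounds named here.

Compound 1, `CSC[C@H](NC(C)=O)C(=O)CCl`: 80800 nM
Compound 2, `CCSC[C@H](NC(C)=O)C(=O)CCl`: 99900 nM
Compound 3, `CCCCCSC[C@H](NC(C)=O)C(=O)CCl`: 5400 nM

All three values come from a functional assay on MOLT-3 cells (Homo sapiens); on this read-out lower numbers stand for stronger inhibition and higher numbers for weaker inhibition. Compound 3 gives the lowest of the three numbers; its nearest neighbour is compound 1, separated by a 15-fold lower number from compound 1 to compound 3 (1.18 log units; beyond the scatter), and compound 2 lies further off, with a 19-fold lower number from compound 2 to compound 3 (1.27 log units; beyond the scatter). Between compound 1 and compound 2 the difference is only a 1.2-fold higher number from compound 1 to compound 2 (0.09 log units; within the scatter), so those two cannot be ordered.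

Compound 4, `CCCCCCCCCSC[C@H](NC(C)=O)C(=O)CCl`, has not yet been measured in this assay. Against compound 3 its structure differs as follows: butyl in place of hydrogen on a saturated chain carbon, five bonds along the chain from a sulfur. For the measured compounds named here, the steps that bear on this are the two that lengthened the chain on the sulfur, a 15-fold lower number from compound 1 to compound 3 (1.18 log units; beyond the scatter) and a 19-fold lower number from compound 2 to compound 3 (1.27 log units; beyond the scatter), both large and in the lowering direction, whereas the short lengthening in a 1.2-fold higher number from compound 1 to compound 2 (0.09 log units; within the scatter) stayed within the scatter. Going by the values given here, the new extension in compound 4 sits further out along the chain than anything measured so far, and no pair among the three covers that region, so the evidence is thinner. For compound 4 the expected step is a 2.7-fold lower number from compound 3 to compound 4 (0.43 log units; beyond the scatter), a further but more modest lowering, since much of the drop was already realised in a 15-fold lower number from compound 1 to compound 3 (1.18 log units; beyond the scatter). Compound 4 is therefore estimated at 2000 nM, with a range from 400 nM to 10000 nM.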

Compound 4, half-maximal inhibitory concentration: 6700 nM
Compound 4: the middle estimate sits 3.4-fold (0.53 log units) below what was measured, within the range that was stated.
By their numbers in this assay, from the lowest: compounds 3 and 4 (each within the scatter of the next); then compounds 1 and 2 (each within the scatter of the next).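

In this assay, butyl in place of hydrogen on a saturated chain carbon, five bonds along the chain from a sulfur, comes with a 1.2-fold higher number from compound 3 to compound 4 (0.09 log units; within the scatter), so this further extension of the chain on the sulfur gives no difference that can be read. The earlier compounds had shown large steps on lengthening this chain, a 15-fold lower number from compound 1 to compound 3 (1.18 log units; beyond the scatter) and a 19-fold lower number from compound 2 to compound 3 (1.27 log units; beyond the scatter), and the new pair shows that such a large step does not recur at this outer part of the chain; together with the short extension in a 1.2-fold higher number from compound 1 to compound 2 (0.09 log units; within the scatter), which also stays within the scatter, it means that lengthening does not lower the number at every step among these four compounds. Nothing available here accounts for why the large steps appear only on going to compound 3.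

The compounds shown leave open how the number behaves at chain lengths that lie between those of compound 3 and compound 4, such as hexyl or octyl, and whether a still longer chain would stay within the scatter of these two. They also leave open what an amine, a carboxylic acid or a phenyl ring on the chain would do at this position.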